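Sulfonylpiperazine acetanilides: alpha3/beta4 modulation, compound 4 outlook

The source may report more compounds than this note shows. Statements on the series, on what has been measured and on what is new or still open speak of the compounds shown alone.

Measured so far:
compound 1, `COc1ccc(NC(=O)CN2CCN(S(=O)(=O)c3ccc(F)cc3)CC2)cc1`: 29600 nM
compound 2, `O=C(CN1CCN(S(=O)(=O)c2ccc(F)cc2)CC1)Nc1ccc(F)cc1`: 11600 nM
compound 3, `O=C(CN1CCN(S(=O)(=O)c2ccccc2F)CC1)Nc1ccccc1F`: 99800 nM

In an in vitro assay on HEK ts201 cells for negative allosteric modulation of Neuronal acetylcholine receptor; alpha3/beta4 (Homo sapiens), read by fluorescence and calcium flux, with a stated time of 1.5 s (on this read-out lower numbers stand for stronger inhibition and higher numbers for weaker inhibition), compound 3 gives the highest number of the three. Among the measured compounds shown here, compound 1 is nearer to it and compound 2 furthest away; compound 3 differs from both in two places, so no single step connects them. For the measured compounds named here, the only one-place step measured, a 2.6-fold lower number from compound 1 to compound 2 (0.41 log units; beyond the scatter), concerns the anilide ring, not the ring on the sulfonyl sulfur, and so bears only loosely on the next change.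

Compound 4, `O=C(CN1CCN(S(=O)(=O)c2cccnc2)CC1)Nc1ccccc1F`, differs from compound 3 by pyridin-3-yl in place of 2-fluorophenyl on a sulfonyl sulfur. Going by the values given here, no measured step alters this ring, so the direction of a 1.7-fold lower number from compound 3 to compound 4 (0.22 log units; within the scatter) is an open estimate; a move of modest size in either sense is expected, not more.

Compound 4 is therefore estimated at 60000 nM in this assay, with a range from 15000 nM to 200000 nM.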

Compound 4, half-maximal inhibitory concentration: 49600 nM
Compound 4: the middle estimate sits 1.2-fold (0.08 log units) above what was measured; measured number inside the range.
By their numbers in this assay, from the lowest: compound 2; then compounds 1, 4 and 3 (each within the scatter of the next, the first and the last beyond it).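

The first step measured at the ring on the sulfonyl sulfur, a 2.0-fold lower number from compound 3 to compound 4 (0.30 log units; within the scatter) in this assay, shows that pyridin-3-yl can stand in place of 2-fluorophenyl with no change beyond the scatter. The entering ring brings a ring nitrogen and a hydrogen-bond acceptor, and the fluorine leaves, yet the read-out cannot separate the two compounds. Nothing at hand explains this result.

From the compounds shown here alone, it remains open whether pyridin-3-yl would read the same with the anilide of compound 2. Also open, going by these compounds, is how an aminophenyl or carboxyphenyl group would read on the sulfonyl sulfur.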